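The source may hold more compounds than are shown below. What is called first, only, known or untested is meant among the compounds shown, and "the series" means these compounds.

Measured compounds:
compound 1 `COc1cc(/C=C/C(=O)/C=C/c2cc(OC)c(OC)c(OC)c2)ccc1OCc1cn(CCOc2cc(=O)oc3ccccc23)nn1`, 89% in a functional assay on HCT-116 cells (Homo sapiens) for inhibition, read by sulforhodamine B assay, with a stated time of 48 h, tested at 50 uM; on this read-out higher numbers stand for more inhibition of growth at the one concentration tested and lower numbers for less inhibition of growth;
compound 2 `COc1ccccc1/C=C/C(=O)/C=C/c1ccc(OCc2cn(CCCCOc3cc(=O)oc4ccccc34)nn2)c(OC)c1`, 43%;
compound 3 `COc1cc(/C=C/C(=O)/C=C/c2cccc3ccccc23)ccc1OCc1cn(CCCOc2cc(=O)oc3ccccc23)nn1`, 66%.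

Compound 2 gives the lowest of the three numbers in this assay: compound 3 lies higher by a gap beyond the scatter, and compound 1 lies higher still, also beyond the scatter. Compound 4 `COc1ccc(/C=C/C(=O)/C=C/c2ccc(OCc3cn(CCCCOc4cc(=O)oc5ccccc45)nn3)c(OC)c2)cc1OC` is not yet measured and differs from compound 2 in one place: 3,4-dimethoxyphenyl in place of 2-methoxyphenyl on a double-bonded chain carbon bound to a double-bonded chain carbon. Among the compounds with values here, no step between two measured compounds isolates this change, so the expectation rests on the spread of the measured values alone. Compound 1 gives 89%, the highest number seen, but it differs from compound 4 in more than one place. The step expected for compound 4, a number 22 percentage points higher from compound 2 to compound 4 (beyond the scatter), is upward and moderate, beyond the scatter. The estimate for compound 4 is 65%, ranging from 40% to 88%.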

Compound 4, percent growth inhibition at one concentration: 55%
The estimate for compound 4 lay 10 percentage points above the measured number; low and high end bracket the measured number.
By their numbers in this assay, from the lowest: compound 2; then compound 4; then compound 3; then compound 1.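

In this assay, within the data shown here, the change to 3,4-dimethoxyphenyl in place of 2-methoxyphenyl on a double-bonded chain carbon bound to a double-bonded chain carbon gives a number 12 percentage points higher from compound 2 to compound 4 (beyond the scatter) and is the first step here that isolates this position. With the rest of the structure held constant, the aryl group at this place alone moves the read-out by a modest amount. Nothing measured here accounts for the step. Going by these compounds, whether a phenyl carrying an amine or a carboxylic acid would do more at this place remains open. So does whether the same change gives a similar step with a shorter chain to the triazole.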